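Series notes: side-chain size and distribution volume

A few compounds are considered here, and "the series" means these few. Any claim that something is new, unique, unknown or untested is made for them only; others in the source may bear on it.

Measured so far:
Compound 1 `CCC(C(=O)O)c1nn(Cc2cn3cc(OCC4CC4)c(Cl)cc3n2)c2ccccc2c1=O`: 60 L/kg
Compound 2 `O=C(O)Cc1nn(Cc2cn3cc(OCC4CC4)c(Cl)cc3n2)c2ccccc2c1=O`: 18 L/kg
Compound 3 `C[C@H](C(=O)O)n1nc(Cn2cc3cc(OCC4CC4)c(Cl)cc3n2)c2ccccc2c1=O`: 168 L/kg

All three numbers come from an ADME assay on the whole organism (Mus musculus, strain CD1) for pharmacokinetics, read by LC-MS, with a stated time of 24 h, at a dose of 1 mg/kg by the intravenous route; a lower number here means that more of the compound stays in the plasma, a higher number that more of the compound sits outside the plasma. Compound 2 stands lowest of the three: compound 1 gives the nearest higher number at 60 L/kg, and compound 3 the furthest at 168 L/kg, both gaps beyond the scatter. Compound 3 differs from compound 2 in more than one place, so its value is noted only as the high end of the range seen.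

The next compound is compound 4 `C[C@H](C(=O)O)c1nn(Cc2cn3cc(OCC4CC4)c(Cl)cc3n2)c2ccccc2c1=O`. It differs from compound 2 by methyl in place of hydrogen on a saturated chain carbon bound to an aromatic carbon and a carbonyl carbon. Among the measured compounds shown here, the one measured step that bears on this is the reverse direction of the same side chain: a 3.3-fold lower number from compound 1 to compound 2 (0.52 log units; beyond the scatter). Going the other way, from hydrogen to ethyl, the number rose by that amount, and methyl lies between hydrogen and ethyl in this series, so a rise smaller than the full step to compound 1 is expected in this assay, beyond the scatter but not reaching the number of compound 1.

For compound 4 the expected step is a 1.9-fold higher number from compound 2 to compound 4 (0.29 log units; within the scatter). The estimate for compound 4 is 35 L/kg, with a range of 18 L/kg to 70 L/kg.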

Compound 4, volume of distribution at steady state: 17 L/kg
Compound 4: middle estimate off by 2.1-fold (0.31 log units), on the high side; the measured number lies below the stated range.
By their numbers in this assay, from the lowest: compounds 4 and 2 (each within the scatter of the next); then compound 1; then compound 3.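

In this assay, methyl in place of hydrogen on a saturated chain carbon bound to an aromatic carbon and a carbonyl carbon gives a 1.1-fold lower number from compound 2 to compound 4 (0.02 log units; within the scatter), so carboxymethyl and 1-carboxyethyl read alike on this side chain. The step that separates compounds on this chain is instead 1-carboxyethyl in place of 1-carboxypropyl, with a 3.5-fold lower number from compound 1 to compound 4 (0.55 log units; beyond the scatter), a step of about the same size as a 3.3-fold lower number from compound 1 to compound 2 (0.52 log units; beyond the scatter); across compound 2, compound 4 and compound 1, the number therefore does not climb evenly with chain size, and the separation appears only with the 1-carboxypropyl group of compound 1. No measurement at hand accounts for this difference between the 1-carboxyethyl and 1-carboxypropyl groups.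

On these data alone, whether a longer chain such as 1-carboxybutyl continues the trend set by compound 1 remains open, as does the effect of the mirror-image form of the 1-carboxyethyl group on this read-out. Also open, as far as these compounds go, is how a primary amide in place of the carboxylic acid would read on this side chain.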